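Two Chlorines Instead of One on a Hydrazone Aryl Group

This account rests on a few compounds, and the source may have more. Where it says the series, first, only, none or still open, it means among the compounds named here.

Measured compounds:
- compound 1 `COc1ccc(OC)c(/C=N/NC(=O)Nc2ccc(Oc3ccnc(-c4nncn4CCN(C)C)c3)c(F)c2)c1`: "not determined" (no result reported)
- compound 2 `CN(C)CCn1cnnc1-c1cc(Oc2ccc(NC(=O)N/N=C/c3ccc(Cl)cc3)cc2F)ccn1`: 1870 nM

These compounds were tested in an ADME assay on WI-38 cells (Homo sapiens) for cytotoxicity, read by MTT assay, with a stated time of 72 h; a higher number here means a weaker inhibitor, a lower number a stronger inhibitor. Going by the values given here, compound 1 has no reported result there, so the only number available belongs to compound 2, which in this assay gives 1870 nM. With a single number, compound 2 can be ranked against nothing; it simply sets the reference point.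

Compound 3 `CN(C)CCn1cnnc1-c1cc(Oc2ccc(NC(=O)N/N=C/c3cccc(Cl)c3Cl)cc2F)ccn1` is the untested partner. Its difference from compound 2 is confined to one spot: 2,3-dichlorophenyl in place of 4-chlorophenyl on a carbon with a double bond to nitrogen. The rest of the shared core, including the urea, the hydrazone and the side chain, is unchanged.

Among the compounds with values here, no pair of measured compounds differs in one place, so there is no comparable step to lean on. Without such a guide, the expectation for this swap is a small step, if any, most likely not beyond the scatter of the method, perhaps a slight move toward a stronger inhibitor. Compound 3 is therefore estimated at 1500 nM in this assay, with a range from 500 nM to 4500 nM, the expected step being a 1.2-fold lower number from compound 2 to compound 3 (0.10 log units; within the scatter).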

Compound 3, half-maximal inhibitory concentration: 6130 nM
Compound 3: middle estimate off by 4.1-fold (0.61 log units), on the low side; measured number above the stated range.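

In this assay, the aryl group on the carbon with a double bond to nitrogen turns out to matter: 2,3-dichlorophenyl in place of 4-chlorophenyl gives a 3.3-fold higher number from compound 2 to compound 3 (0.52 log units; beyond the scatter). Going by these compounds alone, this is the first comparison available for this part of the molecule, and since the urea, the hydrazone and the side chain stay the same, the change in the aryl group alone accounts for the difference between these two compounds, with more of the 2,3-dichlorophenyl compound needed for the same effect on the cells. Nothing at hand explains why the number rises.

The swap alters two things at once, the number of chlorines and where they sit, and a single step cannot separate the two or support a wider pattern. A compound carrying 2-chlorophenyl or 3-chlorophenyl at the same place would help to pull these apart, while plain phenyl, with no chlorine at all, would show what the chlorines of either compound contribute to the number.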